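The source may hold more compounds than are shown below. What is called first, only, known or untested is meant among the compounds shown, and "the series" means these compounds.

Working notes on the step from compound 3 to compound 4. In a functional assay on M14 cells (Homo sapiens) for antiproliferative activity, with a stated time of 72 h (a lower number here means a stronger inhibitor, a higher number a weaker inhibitor), compound 3 (`C=CC[C@H]1C[C@]2([C@@H](C)Cc3cc(O)c(OC)cc3F)OCOC2=CC1=O`) gives 9 nM as its value, compound 2 (`C=CC[C@H]1C[C@]2([C@H](C)Cc3cc(F)c(OC)cc3F)OCOC2=CC1=O`) gives 10 nM and compound 1 (`C=CC[C@H]1C[C@]2([C@@H](C)Cc3cc(OC)c(OC)cc3F)OCOC2=CC1=O`) gives 14 nM on the same read-out. These three numbers lie within the scatter of one another, so compound 3 holds no separate place among them.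

Compound 4 (`C=CC[C@H]1C[C@]2([C@H](C)Cc3cc(O)c(OC)cc3F)OCOC2=CC1=O`) relates to compound 3 as follows: the two compounds have the same atoms and bonds and differ only in configuration as drawn: 1 of 3 stereo elements differ; a stereocentre at a saturated chain carbon is drawn S in compound 3 and R in compound 4. A stereocentre at a saturated chain carbon is thus drawn S in compound 3 and R in compound 4.

For the measured compounds named here, the only measured step, a 1.6-fold lower number from compound 1 to compound 3 (0.19 log units; within the scatter), replaces methyl on an oxygen on an aromatic ring with hydrogen and leaves configuration untouched, so it bears only on how narrow the series has been so far. Going by the values given here, no measured pair isolates this stereocentre. The configuration of compound 4 at that carbon is also drawn in a compound with a different ring substitution, and in this assay that compound, compound 2, gives 10 nM and offers only an indirect hint.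

No change beyond the scatter is expected, and the expected step is a 1.3-fold higher number from compound 3 to compound 4 (0.12 log units; within the scatter) as estimated here, with the upper side left wider. For compound 4 the estimated value is 12 nM, with an expected range from 4 nM to 40 nM on this read-out.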

Compound 4, half-maximal inhibitory concentration: 17 nM
Compound 4: middle estimate off by 1.4-fold (0.15 log units), on the low side; the range from low to high includes it.
By their numbers in this assay, from the lowest: compounds 3, 2, 1 and 4 (each within the scatter of the next).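

In this assay, for the compounds shown here, the first pair to isolate the saturated chain stereocentre gives a 1.9-fold higher number from compound 3 to compound 4 (0.28 log units; within the scatter), so with the hydroxy group held fixed, the S and R drawings at that carbon stay within the scatter of each other. With the R drawing held fixed, a 1.7-fold higher number from compound 2 to compound 4 (0.23 log units; within the scatter), so hydroxy and fluoro on that aromatic carbon are likewise not separated in this series. The first of these steps can be tied to that single stereocentre alone because nothing else separates the pair: the fact that compounds 3 and 4 differ only in the configuration as drawn

Still open is whether an amine or a carboxylic acid on that aromatic carbon would stay within the scatter of these compounds, and whether the S and R drawings would remain this close with such a group in place. Also open, going by these compounds, is whether a longer chain in place of the methyl at the stereocentre would pull the two configurations apart in this assay.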